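The source may hold more compounds than are shown below. What is called first, only, known or untested is meant among the compounds shown, and "the series" means these compounds.

Working notes on the amide series. The shared core of compound 1 `Cc1cc(N(C)C)nc2ccc(NC(=O)c3ccc(Cl)c(Cl)c3)cc12` carries a dimethylamino on an aromatic carbon and a 3,4-dichlorophenyl amide. In a functional assay on SK-BR-3 cells (Homo sapiens) for antiproliferative activity, read by MTT assay, with a stated time of 72 h (on this read-out lower numbers stand for stronger inhibition and higher numbers for weaker inhibition), compound 1 returns only a limit, > 50000 nM, and this is the limit (the limit of > 50000 nM in this assay, at which 1 of the 3 values shown sits). Compound 3 `Cc1cc(N2CCN(C(C)C)CC2)nc2ccc(NC(=O)c3ccc(Cl)c(Cl)c3)cc12` keeps the same amide and puts 4-isopropylpiperazin-1-yl in place of dimethylamino; in this assay compound 3 gives 6680 nM. Among the compounds with values here, that change, an at least 7.4-fold lower number from compound 1 to compound 3 (0.87 log units; beyond the scatter), is the one measured step in the set. Within the data shown here, compound 2 `CCN1CCN(c2cc(C)c3cc(NC(=O)c4ccc(OC)cc4)ccc3n2)CC1`, with a 4-ethylpiperazin-1-yl and a 4-methoxyphenyl amide, gives 9000 nM in this assay; compound 2 and compound 3 sit within the scatter of each other, and compound 2 differs from compound 3 in two places, so no single step connects them.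

Compound 4 `CCN1CCN(c2cc(C)c3cc(NC(=O)c4ccccc4Br)ccc3n2)CC1` is compound 2 with the amide aryl exchanged: 2-bromophenyl in place of 4-methoxyphenyl on a carbonyl carbon. Among the measured compounds shown here, no measured step in the set touches the amide aryl group, so the one step known, from compound 1 to compound 3, gives no direct guide here. The expectation is therefore a step of no more than the scatter, a 1.1-fold higher number from compound 2 to compound 4 (0.05 log units; within the scatter). For compound 4 in this assay the expected value is 10000 nM, with a range from 3000 nM to 35000 nM.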

Compound 4, half-maximal inhibitory concentration: 39200 nM
Beside the measured number, compound 4's estimate is 3.9-fold (0.59 log units) below it; measured number outside the range, above it.
By their numbers in this assay, from the lowest: compounds 3 and 2 (each within the scatter of the next); then compound 4. At a limit, above all of these: compound 1.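

Within the data shown here, with the 4-ethylpiperazin-1-yl held fixed, 2-bromophenyl in place of 4-methoxyphenyl on a carbonyl carbon gives a 4.4-fold higher number from compound 2 to compound 4 (0.64 log units; beyond the scatter) in this assay, the only measured step at the amide aryl group and one beyond the scatter. The other measured step, an at least 7.4-fold lower number from compound 1 to compound 3 (0.87 log units; beyond the scatter), lies at the other place of change, so the number now responds to a change at each of the two places, with a single pair of compounds behind each. Nothing measured in the set gives a cause for the step at the amide aryl group.

A single exchange cannot separate the entry of the 2-bromophenyl from the departure of the 4-methoxyphenyl, and a plain phenyl, a 4-bromophenyl or a phenyl bearing a carboxylic acid or an amine would be needed to tell these apart. Going by these compounds, it also stays open whether the same exchange moves the number in the same direction with 4-isopropylpiperazin-1-yl or dimethylamino in place of 4-ethylpiperazin-1-yl.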